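The source may report more compounds than this note shows. Statements on the series, on what has been measured and on what is new or still open speak of the compounds shown alone.

Compound 1 `Cc1ccc(CNC(=O)c2[nH]c3ccc(Cl)cc3c2S(=O)(=O)c2cc(C)cc(C)c2)cc1` gives 21200 nM in an ADME assay on MT4 cells (Homo sapiens) for cytotoxicity, read by MTT assay; a higher number here means that more compound is tolerated, a lower number that less compound is tolerated. For compound 2 `Cc1cc(C)cc(S(=O)(=O)c2c(C(=O)NCc3ccccc3F)[nH]c3ccc(Cl)cc23)c1` this assay reports only a limit, > 53000 nM. For compound 3 `Cc1cc(C)cc(S(=O)(=O)c2c(C(=O)NCc3ccc(F)cc3)[nH]c3ccc(Cl)cc23)c1` this assay again reports only a limit, > 53000 nM. The step of an at least 2.5-fold higher number from compound 1 to compound 2 (0.39 log units; beyond the scatter) and the step of an at least 2.5-fold higher number from compound 1 to compound 3 (0.39 log units; beyond the scatter) thus both run toward more compound being tolerated, while the step that the two limits leave unreadable from compound 2 to compound 3 cannot be read because of the limit of > 53000 nM in this assay, at which 2 of the 3 values shown sit. Compound 3 therefore stands at a limit rather than at a number, and one other of the three values shown is a limit as well.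

Compound 4 `Cc1cc(C)cc(S(=O)(=O)c2c(C(=O)NCc3ccc(N(C)C)cc3)[nH]c3ccc(Cl)cc23)c1` differs from compound 3 by dimethylamino in place of fluoro on an aromatic carbon. Among the measured compounds shown here, no measured step exchanges these two groups: the steps from compound 1 put fluoro in place of methyl or 2-fluorophenyl in place of 4-methylphenyl, and the step from compound 2 to compound 3 is unreadable. The expected step of an at least 1.1-fold lower number from compound 3 to compound 4 (0.07 log units; that floor lies within the scatter) is accordingly small, with the value most likely sitting at the limit again. Compound 4 is expected at 45000 nM, between 15000 nM and 53000 nM.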

Compound 4, half-maximal cytotoxic concentration: 40700 nM
The estimate for compound 4 lay 1.1-fold (0.04 log units) above the measured number; the range from low to high includes it.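

In this assay compound 4 gives a number, 40700 nM. Among the compounds shown here, at this place the two fluoro compounds give only limits, so dimethylamino is the first group other than methyl at this position to yield a readable value. Measured against compound 1, the exchange is a 1.9-fold higher number from compound 1 to compound 4 (0.28 log units; within the scatter), which places dimethylamino and methyl within the scatter of each other. Against the fluoro compounds the result is an at least 1.3-fold lower number from compound 3 to compound 4 (0.11 log units; that floor lies within the scatter) and an at least 1.3-fold lower number from compound 2 to compound 4 (0.11 log units; that floor lies within the scatter), and both are floors only: the limit of > 53000 nM in this assay, at which 2 of the 4 values shown sit.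

The true size of these two steps and the step between the two fluoro compounds cannot be read. Also open, as far as these compounds go, is how a carboxylic acid or a primary amine would read on this aromatic carbon, para to a large group.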